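Tert-Butyl Ketone on the Hydroxyethoxyphenyl Core: Solubility Outlook

The source may report more compounds than this note shows. Statements on the series, on what has been measured and on what is new or still open speak of the compounds shown alone.

Three compounds have so far been measured in a physicochemical assay for solubility, in phosphate buffer, at pH 6.8; a lower number here means a less soluble compound, a higher number a more soluble compound:

compound 1 `CCC(CC)C1C(C(=O)c2ccc(OC)cc2)=C(O)C(=O)N1c1ccc(-c2ccon2)cc1`, 2200 nM
compound 2 `COc1ccccc1C1C(C(=O)C(C)(C)C)=C(O)C(=O)N1c1ccc(-c2ccon2)cc1`, 29600 nM
compound 3 `COc1ccc(C(=O)C2=C(O)C(=O)N(c3ccc(-c4ccon4)cc3)C2c2ccccc2OCCO)cc1`, > 50000 nM

Compound 3 stands at the top of the range seen so far. Its result in this assay is a limit of the measurement and not a number (the limit of > 50000 nM in this assay, at which 1 of the 3 values shown sits). Compound 1 differs from it in one place, and the step of an at least 22-fold higher number from compound 1 to compound 3 (1.35 log units; beyond the scatter) is large and beyond the scatter. Compound 2, which carries the tert-butyl carbonyl, gives 29600 nM in this assay.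

The compound not yet measured is compound 4 `CC(C)(C)C(=O)C1=C(O)C(=O)N(c2ccc(-c3ccon3)cc2)C1c1ccccc1OCCO`. It differs from compound 3 in one place: tert-butyl in place of 4-methoxyphenyl on a carbonyl carbon. Among the measured compounds shown here, no measured pair isolates this exact change; the only measured step that touches the core of compound 4 is the one from compound 1 to compound 3, which set compound 3 at the limit. Compound 2 shows that the tert-butyl carbonyl is compatible with a high value in this assay, as its result 29600 nM shows. Compound 4 is therefore expected to stay at or near the limit, with the step that the limit leaves unreadable from compound 3 to compound 4 expected to be no larger than the scatter. The estimate for compound 4 is 80000 nM, with a range from 25000 nM to 300000 nM.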

Compound 4, solubility: > 50000 nM
Compound 4 gave a limit, no number (the forecaster's own chance of this, stated with the estimate: 60%); the middle value is on the limit's open side.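

In this assay compound 4 returns a limit and not a number, as compound 3 does: the limit of > 50000 nM in this assay, at which 2 of the 4 values shown sit. Among the compounds shown here, the change from 4-methoxyphenyl to tert-butyl on the carbonyl carbon therefore leaves the result at the limit with the hydroxyethoxyphenyl group held constant, something the earlier compounds could not show, although the size of that step cannot be read from two limits. The other new comparison, hydroxymethyl in place of hydrogen on a saturated chain carbon bound to an oxygen on an aromatic ring, gives an at least 1.6-fold higher number from compound 2 to compound 4 (0.22 log units; that floor lies within the scatter), so this pair does not establish a gain beyond the scatter, even though the true difference may be larger than that floor.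

The compounds shown leave open how far compound 3 and compound 4 lie beyond the limit, and so whether the carbonyl substituent matters at all once the result reaches it. They also leave open whether the high result at this position depends on the hydroxymethyl itself, or would persist with an amine, a carboxylic acid or a longer chain in its place.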